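Isobutyl in Place of 3-Methylphenyl on the Amide Nitrogen

A few compounds are considered here, and "the series" means these few. Any claim that something is new, unique, unknown or untested is made for them only; others in the source may bear on it.

Compound 1 `C=CC1=C(C(=O)Nc2ccccc2OC)C(c2ccc(OC)cc2)OC1` gives > 100000 nM in a functional assay on QGY7701 cells (Homo sapiens) for cytotoxicity, read by MTT assay, with a stated time of 24 h (on this read-out lower numbers stand for stronger inhibition and higher numbers for weaker inhibition), a limit of the assay.
Compound 2 `C=CC1=C(C(=O)Nc2cccc(C)c2)C(c2ccc(F)cc2)OC1` gives 56400 nM in this assay.
Compound 3 `C=CC1=C(C(=O)Nc2ccccc2)C(c2ccc(OC)cc2)OC1` gives > 100000 nM in this assay, a limit of the assay.

Going by the values given here, compound 2 is thus the only compound with a number; the other two values sit at the limit of > 100000 nM in this assay, at which 2 of the 3 values shown sit. Among the compounds with values here, the one step between measured compounds, a step that the two limits leave unreadable from compound 1 to compound 3, concerns the other aromatic ring and runs between two limits, so it says nothing about the amide nitrogen. Compound 4 `C=CC1=C(C(=O)NCC(C)C)C(c2ccc(F)cc2)OC1` differs from compound 2 by isobutyl in place of 3-methylphenyl on an amide-type nitrogen. Within the data shown here, no measured step bears on this change, so the data give no direction for it. The estimate for compound 4 in this assay is 80000 nM, between 25000 nM and 250000 nM. The step from compound 2 to compound 4 is therefore expected to be a 1.4-fold higher number from compound 2 to compound 4 (0.15 log units; within the scatter), with wide uncertainty.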

Compound 4, half-maximal inhibitory concentration: > 100000 nM
Compound 4 ended at the assay's limit; the forecaster's own chance of this, stated with the estimate: 40%; middle value at least 1.2-fold (0.09 log units) away from the limit.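

Going by these compounds alone, on the amide-type nitrogen, isobutyl in place of 3-methylphenyl gives an at least 1.7-fold higher number from compound 2 to compound 4 (0.24 log units; that floor lies within the scatter) in this assay, the only readable step at this position. Its floor lies within the scatter, so the data do not establish a real loss, but isobutyl brings no measurable gain here. Compound 2 remains the only compound with a number: the limit of > 100000 nM in this assay, at which 3 of the 4 values shown sit.

The compounds shown leave open how far beyond the limit compound 4 lies. They also leave open whether a longer chain, a cyclohexyl group or a carboxylic acid on this nitrogen would give a readable number.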